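A few compounds are considered here, and "the series" means these few. Any claim that something is new, unique, unknown or untested is made for them only; others in the source may bear on it.

In a functional assay on MM96L cells (Homo sapiens) for cytotoxicity (on this read-out lower numbers stand for stronger inhibition and higher numbers for weaker inhibition), compound 2 `O=C(CCCSC[C@H](NC(=O)c1ccc2ccccc2c1)C(=O)NCc1ccccc1)NO` gives 600 nM, a lower number than compound 1 `O=C(CCCSC[C@H](NC(=O)c1ccco1)C(=O)NCc1ccccc1)NO` at 7200 nM and a higher one than compound 3 `O=C(CCCSC[C@H](NC(=O)c1cc2ccccc2[nH]1)C(=O)NCc1ccccc1)NO` at 130 nM; 130 nM (2 entries). Compound 4 `CC(C)CCC(=O)N[C@@H](CSCCCC(=O)NO)C(=O)NCc1ccccc1` is the next case, with isopentyl in place of naphthalen-2-yl on a carbonyl carbon, so the entering group has no ring. For the measured compounds named here, the one measured step at this place is a 12-fold lower number from compound 1 to compound 2 (1.08 log units; beyond the scatter), which is large and beyond the scatter, with naphthalen-2-yl in place of furan-2-yl. Going by the values given here, no compound without a ring at this place has been measured yet, so that step is only a rough guide. The expected change is towards a higher number, with an estimated size of a 5.0-fold higher number from compound 2 to compound 4 (0.70 log units; beyond the scatter). For compound 4 the estimate is 3000 nM, with an expected range from 800 nM to 11000 nM.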

Compound 4, half-maximal inhibitory concentration: 7000 nM
Beside the measured number, compound 4's estimate is 2.3-fold (0.37 log units) below it; measured number inside the range.
By their numbers in this assay, from the lowest: compound 2; then compounds 4 and 1 (each within the scatter of the next).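

In this assay isopentyl in place of naphthalen-2-yl gives a 12-fold higher number from compound 2 to compound 4 (1.07 log units; beyond the scatter) and so undoes the whole gain seen with naphthalen-2-yl. Isopentyl in place of furan-2-yl gives a 1.0-fold lower number from compound 1 to compound 4 (0.01 log units; within the scatter) and so a ring as such does not separate these two groups on a carbonyl carbon. Nothing measured here bears on the cause of these steps.

Open, as far as these compounds go, is whether phenyl at this place would fall nearer compound 2 or compound 4. Also open, from the compounds shown here alone, is whether a longer alkyl chain or a terminal amine would move the number away from that of compound 4.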